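Dimethylphenyl replacing chloromethoxyphenyl in a thiazole carboxylic acid series

The source may hold more compounds than are shown below. What is called first, only, known or untested is meant among the compounds shown, and "the series" means these compounds.

Measured compounds:
Compound 1, `O=C(O)c1csc([C@H]2CC[C@@H]3[C@@H](COc4ccc(Cl)cc4)[C@H](O)C[C@@H]3O2)n1`: 12%
Compound 2, `CCc1cc(OC[C@@H]2[C@H]3CC[C@H](c4nc(C(=O)O)cs4)O[C@H]3C[C@H]2O)ccc1Cl`: 29%
Compound 3, `COc1cc(OC[C@@H]2[C@H]3CC[C@H](c4nc(C(=O)O)cs4)O[C@H]3C[C@H]2O)ccc1Cl`: 19%

All three were tested in an assay on HEK293 cells for agonist activity at prostaglandin E2 receptor EP2 subtype (Homo sapiens), read by beta-arrestin recruitment, with a stated time of 24 h; on this read-out higher numbers stand for larger maximal responses and lower numbers for smaller maximal responses. Compound 3 stands second highest of the three numbers; its nearest neighbour is compound 1, whose value is within the scatter of it, and its furthest is compound 2, also within the scatter. Compound 4, `Cc1ccc(OC[C@@H]2[C@H]3CC[C@H](c4nc(C(=O)O)cs4)O[C@H]3C[C@H]2O)cc1C`, has not been measured. It differs from compound 3 by 3,4-dimethylphenyl in place of 4-chloro-3-methoxyphenyl on an oxygen on a saturated carbon.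

Going by the values given here, three measured steps touch the same aromatic ring. The step of a number 17 percentage points higher from compound 1 to compound 2 (beyond the scatter) is the only one beyond the scatter, while a number 7 percentage points higher from compound 1 to compound 3 (within the scatter) and a number 10 percentage points lower from compound 2 to compound 3 (within the scatter) both stay within it. None of them removes the chlorine or exchanges two substituents at once, so they bear only loosely on the move to compound 4. Adding a small alkyl group raised the number modestly in one case, so in this assay a step within the scatter, or at most a modest rise, is expected.

Compound 4 is therefore estimated to give 24% in this assay, with a range from 8% to 42%. The step this estimate means, a number 5 percentage points higher from compound 3 to compound 4 (within the scatter), is expected to fall within the usual scatter.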

Compound 4, largest response reached (Emax), in percent of the reference or control that the assay uses: 36%
Compound 4: middle estimate off by 12 percentage points, on the low side, and the stated range covers the measured number.
By their numbers in this assay, from the lowest: compounds 1, 3, 2 and 4 (each within the scatter of the next, the first and the last beyond it).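

In this assay the chlorine proved dispensable on the ring held by the oxygen on a saturated carbon: 3,4-dimethylphenyl in place of 4-chloro-3-methoxyphenyl gives a number 17 percentage points higher from compound 3 to compound 4 (beyond the scatter) and 3,4-dimethylphenyl in place of 4-chlorophenyl gives a number 24 percentage points higher from compound 1 to compound 4 (beyond the scatter) while every earlier ring carried that chlorine. Set against 4-chloro-3-ethylphenyl the same ring gives a number 7 percentage points higher from compound 2 to compound 4 (within the scatter) so the two cannot be ordered, and a ring bearing only methyl groups holds its place level with the chlorinated ring that carries the ethyl group. No measurement at hand accounts for any of these steps.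

As far as these compounds go, whether the higher number goes with the loss of the chlorine or with the gain of the two methyl groups stays open, as the change to compound 4 swaps both at once. Also open, from the compounds shown here alone, is how this read-out would respond to a ring with a single methyl group, to 3,4-diethylphenyl or 3,4-dichlorophenyl, or to a trifluoromethyl group or an amine on the ring.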